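Replacing pyridin-2-yl with 1-methylcyclopropyl in compound 1

This account rests on a few compounds, and the source may have more. Where it says the series, first, only, none or still open, it means among the compounds named here.

In a functional assay on a cell-free system (plasma, Homo sapiens), with a stated time of 3 min (on this read-out lower numbers stand for stronger inhibition and higher numbers for weaker inhibition), compound 1 (`O=C(NCc1cc(Cl)ccc1-n1cnnn1)[C@@H]1[C@@H]2C[C@@H]2CN1C(=O)[C@H](O)Cc1ccccn1`) gives 1700 nM against compound 2 (`O=C(NCc1cc(Cl)ccc1-n1cnnn1)[C@@H]1[C@H]2C[C@H]2CN1C(=O)[C@H](O)c1ccccc1`) at 960 nM and compound 3 (`O=C(NCc1cc(Cl)ccc1-n1cnnn1)[C@@H]1[C@H]2C[C@H]2CN1C(=O)[C@H](O)Cc1ccccc1`) at 1200 nM so compound 1 lies within the scatter of both.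

Compound 4 (`CC1(C[C@@H](O)C(=O)N2C[C@H]3C[C@H]3[C@H]2C(=O)NCc2cc(Cl)ccc2-n2cnnn2)CC1`) carries 1-methylcyclopropyl in place of pyridin-2-yl on a saturated chain carbon, two bonds along the chain from a carbonyl carbon and an oxygen on a saturated carbon.

Going by the values given here, the one measured step on this side chain is a 1.3-fold higher number from compound 2 to compound 3 (0.10 log units; within the scatter) for benzyl in place of phenyl, a different change that bears only indirectly. Among the compounds with values here, no measured pair replaces an aromatic ring with a saturated one, so the exchange itself is untested. Within the data shown here, with that small step as the only guide, no step beyond the scatter is expected in this assay and the direction stays open. The expected step is a 1.3-fold lower number from compound 1 to compound 4 (0.12 log units; within the scatter) and it remains a weak estimate. Compound 4 is estimated at 1300 nM with an expected range from 450 nM to 3800 nM for now.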

Compound 4, half-maximal inhibitory concentration: 500 nM
Compound 4: the middle estimate sits 2.6-fold (0.41 log units) above what was measured, and the stated range covers the measured number.
By their numbers in this assay, from the lowest: compounds 4, 2, 3 and 1 (each within the scatter of the next, the first and the last beyond it).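

In this assay, going by these compounds alone, the change from (pyridin-2-yl)methyl to (1-methylcyclopropyl)methyl gives a 3.4-fold lower number from compound 1 to compound 4 (0.53 log units; beyond the scatter) and is the only step in this set beyond the scatter, while the earlier side-chain step gives a 1.3-fold higher number from compound 2 to compound 3 (0.10 log units; within the scatter) and stays within it. This position therefore does not need the six-membered aromatic ring with 1 hetero atom: a three-membered non-aromatic ring of carbon only, with fewer heavy atoms and no hydrogen-bond acceptor, gives the lower number. Nothing available explains this step, so it stands as an observation only.

This single exchange cannot separate the loss of the ring nitrogen, the loss of aromaticity and the presence of the methyl group. Also open, on these data alone, is how an unsubstituted cyclopropyl, a tert-butyl or a dimethylamino group would read at this place.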